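The source may report more compounds than this note shows. Statements on the series, on what has been measured and on what is new or still open speak of the compounds shown alone.

In an ADME assay on MDCK-II cells (Canis lupus familiaris) for permeability, at pH 7.4 (on this read-out higher numbers stand for higher permeability and lower numbers for lower permeability), compound 1 (`C[C@@H]1[C@@H]2CN(c3nc(Nc4cnn(C)c4)ncc3F)C[C@]12NC(=O)[C@H]1C[C@@H]1C#N`) gives 13.8 10^-6 cm/s and compound 2 (`C[C@@H]1[C@@H]2CN(c3nc(Nc4cnn(C)c4)ncc3F)C[C@]12NC(=O)[C@@H]1C[C@H]1C#N`) gives 12.9 10^-6 cm/s as its value, so the two stand level within the scatter. Within the data shown here, the only measured step (a 1.1-fold lower number from compound 1 to compound 2 (0.03 log units; within the scatter)) goes with the fact that compounds 1 and 2 differ only in the configuration as drawn and leaves every atom in place.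

Compound 3 (`C[C@@H]1[C@@H]2CN(c3nc(Nc4cnn(CCO)c4)ncc3F)C[C@]12NC(=O)[C@H]1C[C@@H]1C#N`) has the configuration of compound 1 but changes the atoms at one place: hydroxymethyl in place of hydrogen on a saturated chain carbon bound to an aromatic nitrogen describes it. In words, hydroxymethyl stands in place of hydrogen on a saturated chain carbon bound to an aromatic nitrogen, so methyl becomes 2-hydroxyethyl. The step between compound 1 and compound 2 concerns configuration alone, so it gives no direct measure for this change, and the estimate has to rest on the structural change itself. The entering group brings a hydrogen-bond donor and a hydrogen-bond acceptor to a compound that otherwise stays the same. The step expected in this assay is a 2.3-fold lower number from compound 1 to compound 3 (0.36 log units; beyond the scatter) and would be a lower number, probably a little beyond the scatter, with its size uncertain. Compound 3 is estimated at 6 10^-6 cm/s (expected range 2.5 10^-6 cm/s to 11 10^-6 cm/s).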

Compound 3, apparent permeability in the MDCK-II assay: 1.2 10^-6 cm/s
Compound 3: middle estimate off by 5.0-fold (0.70 log units), on the high side, and the stated range ends above it.
By their numbers in the MDCK-II assay, from the lowest: compound 3; then compounds 2 and 1 (each within the scatter of the next).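

Compounds 1 and 2 kept the same atoms and changed only in configuration, so they said nothing about this place on the molecule. Compound 3 shows that the place matters: in the MDCK-II assay, the change from 1-methyl-1H-pyrazol-4-yl to 1-(2-hydroxyethyl)-1H-pyrazol-4-yl gives a 12-fold lower number from compound 1 to compound 3 (1.06 log units; beyond the scatter), even though only a small hydroxymethyl group has entered on a saturated chain carbon bound to an aromatic nitrogen. In a physicochemical assay for lipophilicity, at pH 7.4 (a higher number here means a more lipophilic compound, a lower number a more polar compound), compound 1 gives 2.32 and compound 3 gives 1.75. The same change also lowers the number in the physicochemical assay, and this measured shift may account for part of the loss, although a single pair cannot show how much: the measured distribution coefficient of compound 1, 2.32, and of compound 3, 1.75, a number 0.57 log units lower (beyond the scatter).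

The compounds shown leave open whether the loss belongs to the hydroxyl group itself or to the longer chain, and a plain ethyl or a 2-methoxyethyl group at this place would help to separate the two. They also leave open whether the 2-hydroxyethyl group would have the same effect in the configuration of compound 2, and how an amine or a carboxylic acid at the end of the chain would compare.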